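Working notes on cytotoxicity in a small nitrile series

This account rests on a few compounds, and the source may have more. Where it says the series, first, only, none or still open, it means among the compounds named here.

In an ADME assay on BJ cells (Homo sapiens) for cytotoxicity, with a stated time of 72 h (on this read-out lower numbers stand for an effect already at smaller amounts and higher numbers for an effect only at larger amounts of compound), compound 1 `CCc1ccc(-c2nc3c(c(C)nn3-c3ccccc3)c(-c3ccccc3Cl)c2C#N)cc1` returns only the assay limit > 20000 nM rather than a number. For the measured compounds named here, compound 2 `Cc1nn(-c2ccccc2)c2nc(-c3ccc(C(C)C)cc3)c(C#N)c(-c3ccccc3O)c12` gives 22600 nM in this assay, the only plain number in the set. The remaining value is a limit (the limit of > 20000 nM in this assay, at which 1 of the 2 values shown sits). Compound 3 `Cc1nn(-c2ccccc2)c2nc(-c3ccc4c(c3)CCCC4)c(C#N)c(-c3ccccc3O)c12` differs from compound 2 by 1,2,3,4-tetrahydronaphthalen-6-yl in place of 4-isopropylphenyl on an aromatic carbon. Going by the values given here, no measured step connects these two structures, so the change is expected to shift the read-out by no more than a 1.0-fold lower number from compound 2 to compound 3 (0.01 log units; within the scatter), a move within the usual scatter. Compound 3 is accordingly estimated at 22000 nM in this assay, with a range from 8000 nM to 60000 nM.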

Compound 3, half-maximal effective concentration: > 20000 nM
Compound 3 ended at the assay's limit (the forecaster's own chance of this, stated with the estimate: 50%); the middle value lies beyond the limit too.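

For the compounds shown here, compound 3 returns only a limit, > 20000 nM, so no step from compound 2 to compound 3 can be read in this assay. The compounds shown leave open whether any group on the shared core would give a clearly lower number: the limit of > 20000 nM in this assay, at which 2 of the 3 values shown sit.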